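Cyano in Place of Methylsulfonyl

The source may hold more compounds than are shown below. What is called first, only, known or untested is meant among the compounds shown, and "the series" means these compounds.

Going by the values given here, in a functional assay on MCF7 cells (Homo sapiens) for antiproliferative activity, read by CellTiter-Glo, with a stated time of 5 days (on this read-out lower numbers stand for stronger inhibition and higher numbers for weaker inhibition), compound 2 (`CC1=C(c2cccc(S(C)(=O)=O)c2)C(c2ccc(OC[C@H](C)N3CC[C@@H](C)C3)cc2)Oc2ccc(O)cc21`) gives 4.3 nM, the highest number of the three measured so far and beyond the scatter of both others. Compound 1 (`CC1=C(c2cccc(O)c2)[C@H](c2ccc(OC[C@H](C)N3CC[C@@H](C)C3)cc2)Oc2ccc(O)cc21`) gives 0.1 nM and compound 3 (`CC1=C(c2cccc(O)c2)C(c2ccc(OC[C@@H](C)N3CC[C@@H](C)C3)cc2)Oc2ccc(O)cc21`) gives 0.2 nM. Both carry a hydroxyl group where compound 2 has methylsulfonyl.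

Compound 4 (`CC1=C(c2cccc(C#N)c2)C(c2ccc(OC[C@H](C)N3CC[C@@H](C)C3)cc2)Oc2ccc(O)cc21`) has not been measured. Its change from compound 2 is cyano in place of methylsulfonyl on an aromatic carbon.

Among the compounds with values here, no measured step makes this swap. The only one available, a 2.0-fold higher number from compound 1 to compound 3 (0.30 log units; within the scatter), lies within the scatter and concerns stereochemistry alone, so it says little here. Still, the gap between compound 2 at 4.3 nM and compound 3 at 0.2 nM shows that the group at this place can shift the number considerably. A moderate move towards stronger inhibition in this assay is therefore expected, an estimated 2.9-fold lower number from compound 2 to compound 4 (0.46 log units; beyond the scatter). For compound 4 the expected value is 1.5 nM, with an estimated range from 0.4 nM to 5.5 nM.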

Compound 4, half-maximal inhibitory concentration: 2.6 nM
For compound 4 the middle estimate is 1.7-fold (0.24 log units) below the measured one, within the range that was stated.
By their numbers in this assay, from the lowest: compounds 1 and 3 (each within the scatter of the next); then compounds 4 and 2 (each within the scatter of the next).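

In this assay, going by these compounds alone, this is the first step that changes only the group at this aromatic carbon, and it gives a 1.7-fold lower number from compound 2 to compound 4 (0.22 log units; within the scatter). Methylsulfonyl and cyano therefore cannot be told apart here, even though cyano has fewer heavy atoms and no sulfur, so this position tolerates this exchange without a change beyond the scatter. Nothing available explains why the two groups give such close numbers.

Compounds 1 and 3 carry a hydroxyl group at this place but also differ from compound 2 and compound 4 in their drawn configuration, which leaves the effect of hydroxyl alone unread. As far as these compounds go, how an amine, a carboxylic acid or a longer chain at this place would compare with cyano also remains open.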